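This account rests on a few compounds, and the source may have more. Where it says the series, first, only, none or still open, it means among the compounds named here.

Working notes on the series. Three compounds sharing one core have been run in a functional assay on MDA-MB-231 cells (Homo sapiens) for inhibition, read by sulforhodamine B assay, tested at 10 uM; on this read-out lower numbers stand for less inhibition and higher numbers for more inhibition at the one concentration tested (going by the name of the read-out). Compound 1 `CN1CCN(c2ccc(C3=NN(S(C)(=O)=O)C(c4ccc(N(C)C)cc4)C3)cc2)CC1` gives 0.6% in this assay. Compound 2 `Cc1ccc(S(=O)(=O)N2N=C(c3ccc(N4CCN(C)CC4)cc3)CC2c2ccc(N(C)C)cc2)cc1` gives 10.7% in this assay. Compound 3 `CN(C)c1ccc(C2CC(c3ccc(-n4cncn4)cc3)=NN2S(C)(=O)=O)cc1` gives 7.8% in this assay. Compound 1 and compound 2 differ in one place, (4-methylphenyl in place of methyl on a sulfonyl sulfur), and this change made a step of a number 10.1 percentage points higher from compound 1 to compound 2 (beyond the scatter). Compound 2 and compound 3 are not joined by a single change, and their two values lie close together.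

Compound 4 `Cc1ccc(S(=O)(=O)N2N=C(c3ccc(-n4cncn4)cc3)CC2c2ccc(N(C)C)cc2)cc1` has not yet been measured. It differs from compound 3 in one place, (4-methylphenyl in place of methyl on a sulfonyl sulfur), which is the same change as that from compound 1 to compound 2, sitting in both pairs on a sulfonyl sulfur whose other neighbours are a sulfonamide nitrogen in a ring. The cores of the two pairs differ by 1H-1,2,4-triazol-1-yl in place of 4-methylpiperazin-1-yl on an aromatic carbon, a change that on its own gave a step of a number 7.2 percentage points higher from compound 1 to compound 3 (within the scatter) in this assay.

The step from compound 3 to compound 4 in this assay is expected to be about a number 10.2 percentage points higher from compound 3 to compound 4 (beyond the scatter), set beside the earlier a number 10.1 percentage points higher from compound 1 to compound 2 (beyond the scatter), and rests on that single measured instance of the change. Compound 4 is therefore estimated at 18% in this assay, with a range from 6% to 32% that is wide because the expectation rests on one step only, a number 10.1 percentage points higher from compound 1 to compound 2 (beyond the scatter).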

Compound 4, a percentage reported as inhibition, at one concentration (the size of the read-out at that concentration, not a potency): 20.7%
Beside the measured number, compound 4's estimate is 2.7 percentage points below it; the range from low to high includes it.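

On the core carrying 1H-1,2,4-triazol-1-yl, 4-methylphenyl in place of methyl on a sulfonyl sulfur gives a number 12.9 percentage points higher from compound 3 to compound 4 (beyond the scatter) in this assay, and this step does not differ beyond the scatter from the one seen on the core carrying 4-methylpiperazin-1-yl: the same change on two cores in this assay, a number 10.1 percentage points higher (beyond the scatter) from compound 1 to compound 2 and a number 12.9 percentage points higher (beyond the scatter) from compound 3 to compound 4, 2.8 percentage points apart, within the scatter of two such steps. The other change, 1H-1,2,4-triazol-1-yl in place of 4-methylpiperazin-1-yl on an aromatic carbon, gives a number 10 percentage points higher from compound 2 to compound 4 (within the scatter), a step inside the scatter that reads alike whichever group sits on the sulfonyl sulfur: the same change on two cores in this assay, a number 7.2 percentage points higher (within the scatter) from compound 1 to compound 3 and a number 10 percentage points higher (within the scatter) from compound 2 to compound 4, 2.8 percentage points apart, within the scatter of two such steps. For the compounds shown here, the sulfonyl change therefore carries from one core to the other across these four compounds, but this rests on only two pairs, in one cell line and at one concentration, so it shows neither a general rule for the series nor anything about potency or the reason for the step.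

Still open, from the compounds shown here alone, is whether the step holds for other groups on the sulfonyl sulfur, such as an ethyl chain, an unsubstituted phenyl or a 4-fluorophenyl. Also open, going by these compounds, is how the read-out responds when the ring on the aromatic carbon gives way to an open-chain amine or a carboxylic acid.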